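This account rests on a few compounds, and the source may have more. Where it says the series, first, only, none or still open, it means among the compounds named here.

compound 1 `Cc1cccc(S(=O)(=O)N2CCC(N3CCC(C)CC3)CC2)c1` — in an ADME assay on HCT-116 cells (Homo sapiens) for cytotoxicity, read by CellTiter-Glo, with a stated time of 72 h (on this read-out higher numbers stand for weaker inhibition and lower numbers for stronger inhibition), compound 1 gives > 5000 nM, a limit of the assay.
compound 2 `CC1CCN(C2CCN(S(=O)(=O)c3ccccc3Br)CC2)CC1` — in this assay compound 2 gives > 5000 nM, likewise only a limit.

Compound 2 therefore stands at the limit in this assay with no number of its own; both values shown sit there (the limit of > 5000 nM in this assay, at which 2 of the 2 values shown sit). For the measured compounds named here, the one step on the same sulfonyl sulfur, a step that the two limits leave unreadable from compound 1 to compound 2, is unreadable between two limits, so no measured step gives a size for a change at this position. Compound 3 `CC1CCN(C2CCN(S(=O)(=O)c3cccnc3)CC2)CC1` differs by pyridin-3-yl in place of 2-bromophenyl on a sulfonyl sulfur. With nothing readable to set a direction, compound 3 is expected to remain at the limit, a step that the limit leaves unreadable from compound 2 to compound 3 not beyond the scatter, estimated at 8000 nM (range 3000 nM to 30000 nM).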

Compound 3, half-maximal inhibitory concentration: > 10000 nM
Compound 3 gave a limit, no number; the forecaster's own chance of this, stated with the estimate: 85%; middle value at least 1.2-fold (0.09 log units) from the limit.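

In this assay compound 3 gives > 10000 nM, a limit. The steps among compound 1, compound 2 and compound 3 therefore cannot be read. The compounds shown leave open whether 3-methylphenyl, 2-bromophenyl or pyridin-3-yl on the sulfonyl sulfur differ at all in this read-out.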